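The compounds below may be only part of what the source reports. "The series", "measured", "known", "first", "only" and "open" are said of these compounds alone.

Compound 1 `Cc1ccc2[nH]c(C(=O)N3CC(=O)N(Cc4ccccc4)[C@@H](CN4CCC5(CCC5)CC4)C3)cc2c1`: 7800 nM
Compound 2 `COc1cccc(CN2C(=O)CN(C(=O)c3cc4cc(OC)ccc4[nH]3)C[C@@H]2CC2CCCCC2)c1`: > 10000 nM
Compound 3 `COc1ccc2[nH]c(C(=O)N3CC(=O)N(Cc4ccccc4)[C@@H](COC(C)(C)C)C3)cc2c1`: 78200 nM

These three compounds share a core and were tested in an ADME assay on Vero cells (Chlorocebus sabaeus) for cytotoxicity, with a stated time of 7 days; a higher number here means that more compound is tolerated, a lower number that less compound is tolerated. For compound 2 the entry > 10000 nM is a limit of the assay, not a number (the limit of > 10000 nM in this assay, at which 1 of the 3 values shown sits). Of the two numbers that are known, compound 3 gives the higher one, 78200 nM, while compound 1 gives 7800 nM, a gap beyond the usual scatter.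

Compound 4 `COc1ccc2[nH]c(C(=O)N3CC(=O)N(Cc4ccccc4)[C@@H](CN4CCn5cccc5C4)C3)cc2c1` has not yet been measured in this assay. It differs from compound 3 in one place: a group of 9 heavy atoms (7 carbon, 2 nitrogen; one five-membered aromatic ring with 1 hetero atom, one six-membered non-aromatic ring with 2 hetero atoms) in place of a group of 5 heavy atoms (4 carbon, 1 oxygen; no ring), on a saturated chain carbon bound to a saturated ring carbon. Going by the values given here, no measured pair in this set isolates such a change, so the size of the step can only be guessed from the two numbers at hand. Compound 1, which also carries a ring-bearing group with nitrogen at that saturated chain carbon, gives 7800 nM, a lower number than compound 3. On that basis a downward step is expected, beyond the scatter, from compound 3 to compound 4, of about a 5.2-fold lower number from compound 3 to compound 4 (0.72 log units; beyond the scatter). Compound 4 is therefore estimated at 15000 nM, likely between 5000 nM and 50000 nM.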

Compound 4, half-maximal cytotoxic concentration: > 100000 nM
Compound 4: no number, only a limit (the forecaster's own chance of this, stated with the estimate: 20%); at least 6.6-fold (0.82 log units) between middle value and limit.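

Compound 4 gives > 100000 nM in this assay, which is a limit and not a number: the limit of > 100000 nM in this assay, at which 1 of the 4 values shown sits. Going by these compounds alone, this is the first pair in the set that isolates a change at this place, and replacing tert-butoxy with the larger two-ring group, on a saturated chain carbon bound to a saturated ring carbon, gives an at least 1.2-fold higher number from compound 3 to compound 4 (0.10 log units; that floor lies within the scatter). So this place accepts a group with a five-membered aromatic ring and a six-membered non-aromatic ring without any drop in the amount of compound tolerated, although the floor of the step does not by itself establish a rise beyond the scatter.

From the compounds shown here alone, how far the true value of compound 4 lies past the limit stays unknown, so the full size of the step remains open. Also open, going by these compounds, is whether a simple open-chain amine such as dimethylamino, a carboxylic acid or a longer alkoxy chain at the same saturated chain carbon would leave the tolerated amount just as high on this shared core.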